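Amide variation on the shared core: chlorophenyl replaces methylthiazolyl

The compounds below may be only part of what the source reports. "The series", "measured", "known", "first", "only" and "open" are said of these compounds alone.

Compound 3 `Cc1nc(C(=O)Nc2ccc(Cl)c(-c3nnc4c(Cl)cccn34)c2)cs1` carries a 2-methyl-1,3-thiazol-4-yl on the carbonyl carbon of the amide. In a functional assay on A549 cells (Homo sapiens) for antiproliferative activity, read by MTT assay, with a stated time of 72 h (on this read-out higher numbers stand for weaker inhibition and lower numbers for stronger inhibition), compound 3 gives only a limit, > 100000 nM, and no number. Compound 1 `O=C(Nc1ccc(Cl)c(-c2nnc3c(Cl)cccn23)c1)c1ccc(C(F)(F)F)cc1F` likewise returns a limit in this assay, > 100000 nM. Among the measured compounds shown here, compound 2 `O=C(Nc1ccc(Cl)c(-c2nnc3c(Cl)cccn23)c1)c1ccccc1`, the plain phenyl amide, is the one member with a number, 76900 nM in this assay. For the measured compounds named here, the single measured one-point step, an at least 1.3-fold higher number from compound 2 to compound 3 (0.11 log units; that floor lies within the scatter), has to be read against (the limit of > 100000 nM in this assay, at which 2 of the 3 values shown sit). Compound 4 `O=C(Nc1ccc(Cl)c(-c2nnc3c(Cl)cccn23)c1)c1ccc(Cl)cc1` differs from compound 3 by 4-chlorophenyl in place of 2-methyl-1,3-thiazol-4-yl on a carbonyl carbon; this returns a six-membered aromatic ring of carbon only to the carbonyl carbon, as in compound 2 and compound 1. The step from compound 2 to compound 3 bears on this change, in the reverse direction, and was small. Compound 4 is therefore expected to stay near the weak end of the series, with a step of an at least 1.1-fold lower number from compound 3 to compound 4 (0.04 log units; that floor lies within the scatter) no larger than the scatter. The estimate for compound 4 in this assay is 90000 nM, between 40000 nM and 200000 nM, with a fair chance that only a limit is returned.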

Compound 4, half-maximal inhibitory concentration: 73600 nM
Beside the measured number, compound 4's estimate is 1.2-fold (0.09 log units) above it; low and high end bracket the measured number.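

Chloro in place of hydrogen on an aromatic carbon gives a 1.0-fold lower number from compound 2 to compound 4 (0.02 log units; within the scatter) in this assay, so at this position the phenyl amide and the 4-chlorophenyl amide cannot be told apart. The change from the thiazole gives an at least 1.3-fold lower number from compound 3 to compound 4 (0.13 log units; that floor lies within the scatter), and this printed size is only a floor, so it shows no separation of the two amides either. The value of compound 3 in this step is a limit and not a number, and the series still rests partly on such values: the limit of > 100000 nM in this assay, at which 2 of the 4 values shown sit.

Going by these compounds, how far compound 3 and compound 1 lie past that limit remains open, and with it the true size of the step to compound 4. Also open, on these data alone, is whether an amine or a carboxylic acid on the aromatic ring of the amide would give a number clearly lower than those of compound 2 and compound 4.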